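The source may hold more compounds than are shown below. What is called first, only, known or untested is meant among the compounds shown, and "the series" means these compounds.

Measured compounds in the series:
- compound 1 `COc1ccc(S(=O)(=O)Nc2ccc(CCc3ccc(C(=O)Nc4ccccc4N)cc3)cc2)cc1` — > 10000 nM
- compound 2 `COc1ccc(S(=O)(=O)Nc2ccccc2CCc2ccc(C(=O)Nc3ccccc3)cc2)cc1` — 137 nM
- compound 3 `COc1ccc(S(=O)(=O)Nc2ccccc2CCc2ccc(C(=O)Nc3cc(F)ccc3N)cc2)cc1` — 66 nM

In a functional assay on KB cells (Homo sapiens) for antiproliferative activity, read by sulforhodamine B assay, with a stated time of 48 h (a lower number here means a stronger inhibitor of growth, a higher number a weaker inhibitor of growth), compound 1 gives > 10000 nM, which is a limit of the assay and not a number. It sits at the limit of > 10000 nM in this assay, at which 1 of the 3 values shown sits. Compound 2 gives 137 nM and compound 3 gives 66 nM. Among the compounds with values here, the one measured step, a 2.1-fold lower number from compound 2 to compound 3 (0.32 log units; beyond the scatter), concerns the group on the amide-type nitrogen and not the site that changes here.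

Compound 4 `Nc1ccccc1NC(=O)c1ccc(CCc2ccccc2)cc1` differs from compound 1 by hydrogen in place of ((4-methoxyphenyl)sulfonyl)amino on an aromatic carbon. No measured step touches the ((4-methoxyphenyl)sulfonyl)amino group, so the numbers shown do not anchor this change. Compound 1 stands at the limit, and the two compounds with a measured number, compound 2 and compound 3, both keep the ((4-methoxyphenyl)sulfonyl)amino group. Nothing in the data shows that taking it away recovers growth inhibition. The expected step that the limit leaves unreadable from compound 1 to compound 4 is therefore small, with a real chance that compound 4 also returns only a limit. Compound 4 is estimated at 12000 nM, within a range of 3000 nM to 50000 nM.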

Compound 4, concentration for 50% growth inhibition: > 10000 nM
Compound 4 gave a limit, no number (the forecaster's own chance of this, stated with the estimate: 60%); the middle value does not contradict the limit.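

Compound 4 gives > 10000 nM, a limit of the assay and not a number. Within the data shown here, compound 1 also stands at a limit, so no step from compound 1 to compound 4 can be read: the limit of > 10000 nM in this assay, at which 2 of the 4 values shown sit.

The compounds shown leave open whether taking away the ((4-methoxyphenyl)sulfonyl)amino group changes growth inhibition at all in this assay.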